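A Halogen Swap on the Benzyl Arm

The compounds below may be only part of what the source reports. "The series", "measured", "known", "first", "only" and "open" are said of these compounds alone.

Three compounds have been measured in an assay on isolated protein for inhibition of Amine oxidase [flavin-containing] B (Homo sapiens), read by fluorescence, with stated times of 15 min and 20 min; on this read-out higher numbers stand for weaker inhibition and lower numbers for stronger inhibition:

Compound 1, `Cc1ccccc1CN1CCC(CCNC(=O)/C=C/c2cc(C(C)(C)C)c(O)c(C(C)(C)C)c2)CC1`, gives 7200 nM.
Compound 2, `CC(C)(C)c1cc(/C=C/C(=O)NCCC2CCN(Cc3ccc(F)cc3F)CC2)cc(C(C)(C)C)c1O`, gives 12500 nM.
Compound 3, `CC(C)(C)c1cc(/C=C/C(=O)NCCC2CCN(Cc3cccc(Cl)c3)CC2)cc(C(C)(C)C)c1O`, gives 8700 nM.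

All three share one core and differ only in the aryl group on a saturated chain carbon bound to an amine nitrogen in a ring. Compound 3 holds the second highest of the three numbers; its nearest neighbour is compound 1 and its furthest is compound 2, and in this assay the gap to either is within the scatter.

The unmeasured compound 4, `CC(C)(C)c1cc(/C=C/C(=O)NCCC2CCN(Cc3ccc(Br)cc3)CC2)cc(C(C)(C)C)c1O`, arises from compound 3 by 4-bromophenyl in place of 3-chlorophenyl on a saturated chain carbon bound to an amine nitrogen in a ring. Every measured step at this position bears on it: a 1.7-fold higher number from compound 1 to compound 2 (0.24 log units; within the scatter), a 1.2-fold higher number from compound 1 to compound 3 (0.08 log units; within the scatter) and a 1.4-fold lower number from compound 2 to compound 3 (0.16 log units; within the scatter). None of these reaches beyond the scatter, so varying the aryl group here has so far left the number essentially unchanged, and compound 4 is expected to behave the same way.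

For compound 4 the estimate in this assay is 9000 nM, within a range from 4500 nM to 18000 nM. This estimate amounts to a step of a 1.0-fold higher number from compound 3 to compound 4 (0.01 log units; within the scatter), expected to stay within the scatter.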

Compound 4, half-maximal inhibitory concentration: 13200 nM
Compound 4: middle estimate off by 1.5-fold (0.17 log units), on the low side; measured number inside the range.
By their numbers in this assay, from the lowest: compounds 1, 3, 2 and 4 (each within the scatter of the next).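

Replacing 3-chlorophenyl with 4-bromophenyl gives a 1.5-fold higher number from compound 3 to compound 4 (0.18 log units; within the scatter) in this assay and so adds a bromine-bearing aryl group to the set without separating it from the others. The comparison with the fluorinated compound gives a 1.1-fold higher number from compound 2 to compound 4 (0.02 log units; within the scatter) and the widest gap in the series, a 1.8-fold higher number from compound 1 to compound 4 (0.26 log units; within the scatter) against the 2-methylphenyl compound, still does not leave the scatter, so the four aryl groups on a saturated chain carbon bound to an amine nitrogen in a ring cannot be put in any order. No measurement shown here explains why these aryl groups cannot be told apart.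

The step from compound 3 to compound 4 exchanges the halogen and its ring position together, so 3-bromophenyl or 4-chlorophenyl would be needed to read either change alone. The compounds shown also leave open whether any group at this position can move the number beyond the scatter, for example a 4-methoxyphenyl, a pyridine ring or a cyclohexyl group in place of the halogen-bearing or methyl-bearing phenyl rings.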